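This account rests on a few compounds, and the source may have more. Where it says the series, first, only, none or still open, it means among the compounds named here.

Measured compounds:
compound 1 `COc1ccc(-c2c(C#N)c(N)c(C#N)c(SC)c2-c2ccc(OC)cc2)cc1` gives 14.4%
compound 2 `CSc1c(C)c(-c2ccccc2)c(C#N)c(N)c1C#N` gives 6.7%
compound 3 `CSc1c(C)c(-c2ccc(Cl)cc2)c(C#N)c(N)c1C#N` gives 6.7%

All three were tested in an assay on isolated protein for inhibition of Maltase-glucoamylase (Homo sapiens), tested at 100 uM; on this read-out higher numbers stand for more inhibition at the one concentration tested (going by the name of the read-out) and lower numbers for less inhibition. Compound 3 stands level with compound 2 at the digits shown, and the two of them together are the lowest of the three numbers; the gap from compound 3 to compound 1 is within the scatter, so no order among the three can be claimed. Going by the values given here, the only step between two measured compounds that differ in one place is no change at the digits printed from compound 2 to compound 3 (within the scatter).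

Compound 4 `COc1ccc(-c2c(C)c(SC)c(C#N)c(N)c2C#N)cc1` has not yet been measured in this assay. It differs from compound 3 by methoxy in place of chloro on an aromatic carbon. Among the compounds with values here, no measured step replaces chloro by methoxy on this core, so the step from compound 2 to compound 3 is the only one that bears on a change at this place, and it was flat. Compound 1, which carries methoxy on both of its aryl groups, gives 14.4%, a value that differs from compound 3 only within the scatter. Compound 4 is therefore expected to stay close to compound 3, with an expected step of a number 2.3 percentage points higher from compound 3 to compound 4 (within the scatter) that should not exceed the scatter. The estimate for compound 4 is 9%, with a range from 2% to 18%.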

Compound 4, a percentage reported as inhibition, at one concentration (the size of the read-out at that concentration, not a potency): 17.3%
The estimate for compound 4 lay 8.3 percentage points below the measured number, and the stated range covers the measured number.
By their numbers in this assay, from the lowest: compounds 2, 3, 1 and 4 (each within the scatter of the next, the first and the last beyond it).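

In this assay the aromatic carbon para to a large group proves responsive to the group it carries: methoxy in place of chloro gives a number 10.6 percentage points higher from compound 3 to compound 4 (beyond the scatter) and methoxy in place of hydrogen gives a number 10.6 percentage points higher from compound 2 to compound 4 (beyond the scatter) even though chloro in place of hydrogen, with no change at the digits printed from compound 2 to compound 3 (within the scatter) as its step, had shown nothing at this place. Of the three groups seen here on this carbon, methoxy alone separates from the other two, and only modestly, so the earlier flat step spoke for chloro and not for the position as a whole. Methyl in place of 4-methoxyphenyl gives a number 2.9 percentage points higher from compound 1 to compound 4 (within the scatter) so on this read-out compound 4 keeps pace with compound 1 without that second aryl group.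

Nothing at hand accounts for why methoxy parts from chloro and hydrogen here. On these data alone, whether a hydroxyl, an amine or a longer chain such as ethoxy on the same carbon would go with methoxy or with chloro remains open, and each number tells only the size of the effect at a single concentration.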